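The source may hold more compounds than are shown below. What is called first, only, known or untested is meant among the compounds shown, and "the series" means these compounds.

Of the compounds shown here, three have so far been tested in a functional assay on CCRF-CEM cells (Homo sapiens) for cytotoxicity, read by MTT assay, with a stated time of 72 h; a higher number here means a weaker inhibitor of growth, a lower number a stronger inhibitor of growth. Compound 1 `N#C[Se]c1ccc(NC(=O)OCc2ccc([N+](=O)[O-])cc2)cc1` gives 38300 nM. Compound 2 `N#C[Se]c1ccc(NC(=O)Oc2ccc(F)cc2)cc1` gives 41900 nM. Compound 3 `CCCCOC(=O)Nc1ccc([Se][Se]c2ccc(NC(=O)OCCCC)cc2)cc1` gives 44500 nM. Compound 2 has the second highest of the three numbers, yet its gaps to compound 3 and to compound 1 both lie within the usual scatter, so the three cannot be told apart. The step to compound 4 `N#C[Se]c1ccc(NC(=O)Oc2ccccc2)cc1` alters one feature of compound 2: hydrogen in place of fluoro on an aromatic carbon. Going by the values given here, no measured pair shows this same change, so there is nothing to lean on. Compound 4 is expected to stay close to compound 2, the estimated step of a 1.0-fold higher number from compound 2 to compound 4 (0.00 log units; within the scatter) not going beyond the scatter. The expected value for compound 4 is 42000 nM, with a range from 21000 nM to 84000 nM.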

Compound 4, concentration for total growth inhibition: 48000 nM
Compound 4: the middle estimate sits 1.1-fold (0.06 log units) below what was measured; the range from low to high includes it.
By their numbers in this assay, from the lowest: compounds 1, 2, 3 and 4 (each within the scatter of the next).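

In this assay, putting hydrogen in place of fluoro on this aromatic carbon, para to a large group, gives a step of a 1.1-fold higher number from compound 2 to compound 4 (0.06 log units; within the scatter). Going by these compounds alone, this is the first comparison here of compounds that differ in one place, and it shows that fluoro can be lost at this position with no change that stands out from the scatter. No measurement at hand bears on this result. Only this one swap is shown, so it remains open whether an amine or a carboxylic acid at the same position would move the number beyond the scatter.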